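Stereochemical inversion at two ring carbons and microsomal stability

A few compounds are considered here, and "the series" means these few. Any claim that something is new, unique, unknown or untested is made for them only; others in the source may bear on it.

Measured compounds:
compound 1 `COC(=O)N[C@H](C(=O)N1CCC[C@H]1C(=O)Nc1ccc([C@H]2CC[C@H](c3ccc(NC(=O)[C@@H]4CCCN4C(=O)[C@@H](NC(=O)OC)C(C)(C)C)cc3)N2c2ccc(F)cc2)cc1)C(C)(C)C`, 69%
compound 2 `COC(=O)N[C@H](C(=O)N1CCC[C@H]1C(=O)Nc1ccc([C@@H]2CC[C@@H](c3ccc(NC(=O)[C@@H]4CCCN4C(=O)[C@@H](NC(=O)OC)[C@@H](C)OC)cc3)N2c2ccc(F)cc2)cc1)[C@@H](C)OC`, 47%
compound 3 `COC(=O)N[C@H](C(=O)N1CCC[C@H]1C(=O)Nc1ccc([C@@H]2CC[C@@H](c3ccc(NC(=O)[C@@H]4CCCN4C(=O)[C@@H](NC(=O)OC)[C@H]4CCOC4)cc3)N2c2ccc(F)cc2)cc1)[C@H]1CCOC1`, 42%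

In an ADME assay (liver) for metabolic stability, with Liver microsome (Rattus norvegicus) as the target, using microsomes, with a stated time of 30 min (on this read-out higher numbers stand for a more stable compound and lower numbers for a less stable compound), compound 3 gives 42%. Compound 2 gives 47%, a number within the usual scatter of compound 3, so the two cannot be told apart. Compound 1 gives 69% and stands beyond the scatter above compound 3.

Compound 4 `COC(=O)N[C@H](C(=O)N1CCC[C@H]1C(=O)Nc1ccc([C@H]2CC[C@H](c3ccc(NC(=O)[C@@H]4CCCN4C(=O)[C@@H](NC(=O)OC)[C@H]4CCOC4)cc3)N2c2ccc(F)cc2)cc1)[C@H]1CCOC1` keeps every atom and bond of compound 3; the difference is the two compounds have the same atoms and bonds and differ only in configuration as drawn: 2 of 8 stereo elements differ; a stereocentre at a saturated ring carbon is drawn S in compound 3 and R in compound 4; a stereocentre at a saturated ring carbon is drawn S in compound 3 and R in compound 4. Among the measured compounds shown here, no measured pair in this set isolates such a change in configuration, so its effect is unknown here. Compound 4 is expected to land close to compound 3, with a step of a number 6 percentage points higher from compound 3 to compound 4 (within the scatter) that may well fall inside the scatter. The estimated value for compound 4 in this assay is 48%, within 30% to 66%.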

Compound 4, percent of the compound remaining: 46%
For compound 4 the middle estimate is 2 percentage points above the measured one; the measured number falls inside the stated range.
By their numbers in this assay, from the lowest: compounds 3, 4 and 2 (each within the scatter of the next); then compound 1.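

Among the compounds shown here, compounds 3 and 4 form the first pair in this set to isolate configuration at these two saturated ring carbons, drawn S in compound 3 and R in compound 4. In this assay the pair gives a step of a number 4 percentage points higher from compound 3 to compound 4 (within the scatter), so inverting both carbons together has no effect that can be told from the scatter. The comparison involves no other structural change: the fact that compounds 3 and 4 differ only in the configuration as drawn

The compounds shown leave open what inverting only one of the two carbons would do. From the compounds shown here alone, it also remains open whether the inversion would stay this silent with side chains carrying another group, such as an amine.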